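Pyrazole acid series: halogen swap on the benzyl ether

This account rests on a few compounds, and the source may have more. Where it says the series, first, only, none or still open, it means among the compounds named here.

Two compounds of the series have numbers in an assay on CHO-K1 cells for displacement of a labelled ligand from prostaglandin E2 receptor EP1 subtype (Homo sapiens); on this read-out higher numbers stand for weaker inhibition and lower numbers for stronger inhibition. Compound 1 `Cc1cc(C(=O)O)nn1Cc1cc(Br)ccc1OCc1ccc(F)cc1F` gives 0.525 nM in this assay. Among the measured compounds shown here, compound 2 `Cc1cc(C(=O)O)nn1Cc1cc(F)ccc1OCc1ccc(Cl)cc1Cl` gives 355 nM in this assay, the higher of the two numbers, with compound 1 as its only neighbour at a gap well beyond the scatter. Compounds 1 and 2 differ in more than one place, so the gap cannot be assigned to any single change.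

Compound 3 `Cc1cc(C(=O)O)nn1Cc1cc(F)ccc1OCc1ccc(F)cc1F` is not yet measured in this assay. Relative to compound 2 the change is 2,4-difluorophenyl in place of 2,4-dichlorophenyl on a saturated chain carbon bound to an oxygen on an aromatic ring. Compound 3 therefore carries the same 2,4-difluorobenzyl group as compound 1, while the rest of its structure matches compound 2. For the measured compounds named here, no measured pair isolates this swap, so its size is unknown; the spread between compound 1 and compound 2 leaves room for a large step in either direction. The working expectation is a move toward a lower number, of size an 18-fold lower number from compound 2 to compound 3 (1.25 log units; beyond the scatter), with wide uncertainty. Compound 3 is estimated at 20 nM in this assay, within a range of 2 nM to 200 nM.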

Compound 3, half-maximal inhibitory concentration: < 2000 nM
Compound 3 ended at the assay's limit; the forecaster's own chance of this, stated with the estimate: 3%; the middle value does not contradict the limit.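

In this assay compound 3 gives < 2000 nM as a limit of the assay and not a number, so neither step to it, from compound 1 or from compound 2, can be read: the limit of < 2000 nM in this assay, at which 1 of the 3 values shown sits.
The compounds shown leave open what 2,4-difluorobenzyl in place of 2,4-dichlorobenzyl, or fluoro in place of bromo, does on its own.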